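Replacing the pyridin-4-yl group of compound 3

The source may hold more compounds than are shown below. What is called first, only, known or untested is meant among the compounds shown, and "the series" means these compounds.

In an ADME assay on cells (Homo sapiens) for cytotoxicity, read by resazurin assay, with a stated time of 5 days (a lower number here means that less compound is tolerated, a higher number that more compound is tolerated), compound 1 (`COc1ccc(-c2nc(S(=O)(=O)c3cccc(Cl)c3)nc3ccsc23)cn1`) gives > 50000 nM, which is a limit. Compound 2 (`c1ccc(-c2cc(CNc3nncc(-c4cccc5ccccc45)n3)n[nH]2)cc1`) gives > 10000 nM, also a limit. Compound 3 (`O=S(=O)(Cc1nc(-c2ccncc2)c2sccc2n1)c1cccc(Cl)c1`) gives > 50000 nM, again a limit, and so stands at the limit of > 50000 nM in this assay, at which 2 of the 3 values shown sit. No exact number is therefore available for any of the three. Compound 4 (`O=c1ccc(-c2nc(CS(=O)(=O)c3cccc(Cl)c3)nc3ccsc23)c[nH]1`) carries a group with no common name in place of pyridin-4-yl, on an aromatic carbon: a group of 7 heavy atoms (5 carbon, 1 nitrogen, 1 oxygen; one six-membered aromatic ring with 1 hetero atom) in place of a group of 6 heavy atoms (5 carbon, 1 nitrogen; one six-membered aromatic ring with 1 hetero atom), on an aromatic carbon. Within the data shown here, no measured step bears on this exchange. The expectation rests on compound 3 alone, whose limit is > 50000 nM. The estimated move, a number no higher from compound 3 to compound 4 (the limit leaves the size open), is expected to stay within the scatter in this assay. Compound 4 is expected near 50000 nM, within an estimated range of 18000 nM to 80000 nM.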

Compound 4, half-maximal cytotoxic concentration: > 50000 nM
Compound 4 gave a limit, no number (the forecaster's own chance of this, stated with the estimate: 75%); the middle value sits exactly at the limit.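

Among these compounds, compound 3 and compound 4 both gave only a limit in this assay, so no step between them can be read. The compounds shown leave open the actual half-maximal cytotoxic concentration of either compound, and whether replacing pyridin-4-yl changes it.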